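This account rests on a few compounds, and the source may have more. Where it says the series, first, only, none or still open, it means among the compounds named here.

Measured compounds:
- compound 1, `CCN1CCN(c2cccc3c2CN([C@H](CCCNS(=O)(=O)c2c[nH]cn2)c2ccc(OC)c(OC)c2)C3=O)CC1`: 51 nM
- compound 2, `COc1ccc([C@@H](CCCN(C)S(=O)(=O)c2cccs2)N2Cc3c(cccc3N3CCN(C4CCC4)CC3)C2=O)cc1OC`: 510 nM
- compound 3, `CCN1CCN(c2cccc3c2CN([C@H](CCCN(C)S(=O)(=O)c2cccs2)c2ccc(OC)c(OC)c2)C3=O)CC1`: 88 nM

In a functional assay on RMS13 cells for antagonist activity at Urotensin-2 receptor (Homo sapiens), read by FLIPR and calcium flux, with a stated time of 1 h (a higher number here means a weaker inhibitor, a lower number a stronger inhibitor), compound 3 gives 88 nM, the second highest of the three numbers. Its nearest neighbour is compound 1, which gives 51 nM; the step of a 1.7-fold higher number from compound 1 to compound 3 (0.24 log units; within the scatter) lies within the scatter, so the two cannot be ordered. Compound 2 gives 510 nM, and the step of a 5.8-fold lower number from compound 2 to compound 3 (0.76 log units; beyond the scatter) is beyond the scatter.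

Compound 4, `CCN1CCN(c2cccc3c2CN([C@H](CCCNCc2cccs2)c2ccc(OC)c(OC)c2)C3=O)CC1`, has not yet been measured in this assay. It differs from compound 3 in one place: ((thiophen-2-yl)methyl)amino in place of methyl((thiophen-2-yl)sulfonyl)amino on a saturated chain carbon, four bonds along the chain from an amide-type nitrogen in a ring and an aromatic carbon. Among the compounds with values here, the only measured step at this position is a 1.7-fold higher number from compound 1 to compound 3 (0.24 log units; within the scatter), which exchanged one sulfonyl-bearing group for another and stayed within the scatter. Within the data shown here, no measured step removes the sulfonyl group altogether or places a secondary amine there, so the present change is not covered by anything seen so far. The nearby steps give no clear direction; the expectation is therefore a small step, a 1.7-fold higher number from compound 3 to compound 4 (0.23 log units; within the scatter), with wide uncertainty. Compound 4 is estimated at 150 nM in this assay, within a range of 30 nM to 800 nM.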

Compound 4, half-maximal inhibitory concentration: 59 nM
For compound 4 the middle estimate is 2.5-fold (0.41 log units) above the measured one, within the range that was stated.
By their numbers in this assay, from the lowest: compounds 1, 4 and 3 (each within the scatter of the next); then compound 2.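

In this assay, the step from the sulfonamide to the amine is small: a 1.5-fold lower number from compound 3 to compound 4 (0.17 log units; within the scatter). The earlier step at this position only exchanged one sulfonyl-bearing group for another, whereas this one shows that ((thiophen-2-yl)methyl)amino, with no sulfonyl group at all, can stand on this saturated chain carbon without a change beyond the scatter. The second new step, with (thiophen-2-yl)methyl in place of (1H-imidazol-4-yl)sulfonyl on an amine nitrogen, reads a 1.2-fold higher number from compound 1 to compound 4 (0.06 log units; within the scatter), so this position has so far accepted quite different groups, and nothing available explains that tolerance.

Because the step to compound 4 removes both the sulfonyl group and the methyl on the nitrogen, the compounds shown cannot separate the share of each, which a methyl((thiophen-2-yl)methyl)amino group would address. They also leave open whether a benzylamino group, a thiophene-2-carboxamide or a longer chain at this position would stay within the scatter of compound 4.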